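Swapping fluoro for chloro on the indole-type core

A few compounds are considered here, and "the series" means these few. Any claim that something is new, unique, unknown or untested is made for them only; others in the source may bear on it.

Compound 1 `Fc1ccc2[nH]c(-c3nc(-c4ccc(Cl)cc4)no3)cc2c1` carries a fluoro on its shared core. In a functional assay on COLO 320 cells (Homo sapiens) for antiproliferative activity, read by WST assay, with a stated time of 72 h (a lower number here means a stronger inhibitor, a higher number a weaker inhibitor), compound 1 gives only a limit of the assay, > 50000 nM; that reading is the limit of > 50000 nM in this assay, at which 1 of the 3 values shown sits, and not a number. Compound 2 `Clc1ccc(-c2noc(-c3cc4cc(Cl)ccc4[nH]3)n2)cc1` differs from compound 1 by chloro in place of fluoro on an aromatic carbon; in this assay compound 2 gives 25000 nM, a step of an at least 2.0-fold lower number from compound 1 to compound 2 (0.30 log units; that floor lies within the scatter). Compound 3 `COc1ccc(-c2noc(-c3cc4cc(F)ccc4[nH]3)n2)cc1` differs from compound 1 by methoxy in place of chloro on an aromatic carbon; in this assay compound 3 gives 14800 nM, a step of an at least 3.3-fold lower number from compound 1 to compound 3 (0.52 log units; beyond the scatter). The values of compound 2 and compound 3 lie within the scatter of each other, so no order between them can be read.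

Compound 4 `COc1ccc(-c2noc(-c3cc4cc(Cl)ccc4[nH]3)n2)cc1` has not yet been measured in this assay. It differs from compound 3 by chloro in place of fluoro on an aromatic carbon, the same change that separates compound 1 from compound 2, made on the same place of the core. Because the earlier step was an at least 2.0-fold lower number from compound 1 to compound 2 (0.30 log units; that floor lies within the scatter) and its floor lies within the scatter, only a modest gain is expected here. The step expected from compound 3 to compound 4 is a 1.9-fold lower number from compound 3 to compound 4 (0.27 log units; within the scatter). In this assay compound 4 is estimated at 8000 nM, expected to fall between 3000 nM and 25000 nM.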

Compound 4, half-maximal inhibitory concentration: 9600 nM
Compound 4: middle estimate off by 1.2-fold (0.08 log units), on the low side; the measured number falls inside the stated range.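

In this assay, chloro in place of fluoro on an aromatic carbon of the shared core gives a 1.5-fold lower number from compound 3 to compound 4 (0.19 log units; within the scatter), so on this core the change cannot be told apart from the ordinary spread of repeated measurements, and the direction matches the earlier case without showing that the size carries over: the same change on two cores in this assay, an at least 2.0-fold lower number (0.30 log units; that floor lies within the scatter) from compound 1 to compound 2 and a 1.5-fold lower number (0.19 log units; within the scatter) from compound 3 to compound 4; the limit leaves it open whether they differ

The second change, methoxy in place of chloro on an aromatic carbon, gives a 2.6-fold lower number from compound 2 to compound 4 (0.42 log units; beyond the scatter), a modest step that stands clear of that spread and so shows that this change again comes with a lower number on a second core, though not that its size stays the same: the same change on two cores in this assay, an at least 3.3-fold lower number (0.52 log units; beyond the scatter) from compound 1 to compound 3 and a 2.6-fold lower number (0.42 log units; beyond the scatter) from compound 2 to compound 4; the limit leaves it open whether they differ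

Both earlier steps start from compound 1, whose reading is a limit and not a number, so neither change has a fully measured size on the fluoro core with the chloro partner: the limit of > 50000 nM in this assay, at which 1 of the 4 values shown sits.

The compounds shown carry only fluoro or chloro at the one changing place and only chloro or methoxy at the other, so how a nitrile, an amine or a carboxylic acid would behave at either place stays open. From the compounds shown here alone, whether these two changes add up in the same way on other cores, or in other cells, also stays open.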